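The compounds below may be only part of what the source reports. "The series", "measured", "known", "first", "only" and "open" are said of these compounds alone.

- compound 1 `CC1=CCC[C@](C)(CC/C(C)=C/CC2=C(O)C(=O)C=C(N[C@@H](CO)C(=O)O)C2=O)[C@@H]1C` gives > 10 ug/mL
- compound 2 `C=C1[C@H](C)CCC[C@]1(C)CC/C(C)=C/CC1=C(O)C(=O)C=C(N[C@@H](CO)C(=O)O)C1=O` gives > 10 ug/mL

In an ADME assay on KB cells (Homo sapiens) for cytotoxicity, with a stated time of 48 h (on this read-out lower numbers stand for stronger inhibition and higher numbers for weaker inhibition), compound 1 gives > 10 ug/mL, which is a limit of the assay and not a number. Compound 2 gives > 10 ug/mL, also a limit. Compound 1 therefore stands at the limit of > 10 ug/mL in this assay, at which 2 of the 2 values shown sit. Compound 3 `CC1=CCC[C@](C)(CC/C(C)=C/CC2=C(O)C(=O)C=C(N[C@H](C(=O)O)[C@H](C)O)C2=O)[C@@H]1C` differs from compound 1 by methyl in place of hydrogen on a saturated chain carbon bound to an oxygen on a saturated carbon and a saturated chain carbon, which turns hydroxymethyl into 1-hydroxyethyl. Among the measured compounds shown here, the one measured step, a step that the two limits leave unreadable from compound 1 to compound 2, involves a different part of the molecule and gives no size to build on. The expected result is therefore no step beyond the usual scatter, in neither direction, estimated as a step that the limit leaves unreadable from compound 1 to compound 3. Compound 3 is expected at 15 ug/mL, with an estimated range from 7 ug/mL to 40 ug/mL.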

Compound 3, half-maximal inhibitory concentration: > 10 ug/mL
Compound 3 ended at the assay's limit; the forecaster's own chance of this, stated with the estimate: 80%; the middle value does not contradict the limit.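

The step from hydroxymethyl in compound 1 to 1-hydroxyethyl in compound 3 cannot be read, as both values are limits of the assay and not numbers: the limit of > 10 ug/mL in this assay, at which 3 of the 3 values shown sit.

The compounds shown leave open whether any change to this structure would give a true number in this assay.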